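The source may report more compounds than this note shows. Statements on the series, on what has been measured and on what is new or still open speak of the compounds shown alone.

Measured so far in a functional assay on DU-145 cells (Homo sapiens) for cytotoxicity, read by MTT assay, with a stated time of 72 h; on this read-out lower numbers stand for stronger inhibition and higher numbers for weaker inhibition:
compound 1 `COc1cccc(/C=C/C(=O)Nc2cc(C(=O)c3cc(OC)c(OC)c(OC)c3)ccc2OC)c1`: 6200 nM
compound 2 `COc1ccc(C(=O)c2cc(OC)c(OC)c(OC)c2)cc1NC(=O)/C=C/c1ccc(F)cc1`: 3900 nM

Going by the values given here, compound 2 and compound 1 lie within the scatter of each other; the only measured step, a 1.6-fold lower number from compound 1 to compound 2 (0.20 log units; within the scatter), is small. Compound 3 `COc1cc(/C=C/C(=O)Nc2cc(C(=O)c3cc(OC)c(OC)c(OC)c3)ccc2OC)ccc1F` differs from compound 2 by methoxy in place of hydrogen on an aromatic carbon. Among the compounds with values here, it combines the substitution pattern of compound 1 with the fluoro group of compound 2, so the step from compound 1 to compound 2 is the only guide, and it was within the scatter. No step beyond the scatter is therefore expected in this assay. Compound 3 is estimated at 4500 nM, range 2000 nM to 10000 nM, a step of a 1.2-fold higher number from compound 2 to compound 3 (0.06 log units; within the scatter) expected.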

Compound 3, half-maximal inhibitory concentration: 12100 nM
For compound 3 the middle estimate is 2.7-fold (0.43 log units) below the measured one; measured number above the stated range.
By their numbers in this assay, from the lowest: compounds 2, 1 and 3 (each within the scatter of the next, the first and the last beyond it).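

In this assay, going by these compounds alone, methoxy on the aromatic carbon ortho to a fluoro group gives the first step beyond the scatter, with a 3.1-fold higher number from compound 2 to compound 3 (0.49 log units; beyond the scatter) as a modest change. Fluoro in place of hydrogen on the methoxy-bearing ring gives a smaller step, with a 2.0-fold higher number from compound 1 to compound 3 (0.29 log units; within the scatter) lying within the scatter, so this change cannot be read as a clear effect. Nothing measured here accounts for the methoxy step.

Going by these compounds, whether the step at this carbon is particular to methoxy stays open, since hydroxy, ethoxy or an amine there could separate its size from its oxygen. Replacing the fluoro group with chloro would test whether the step depends on that neighbouring group.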